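A few compounds are considered here, and "the series" means these few. Any claim that something is new, unique, unknown or untested is made for them only; others in the source may bear on it.

In a functional assay on MRC5 cells (Homo sapiens) for cytotoxicity, read by colorimetric assay and MTT assay (a lower number here means that less compound is tolerated, a higher number that more compound is tolerated), compound 1 `CCN(CC)c1ccc(/C=N/NC(=O)c2ccc([N+](=O)[O-])cc2)c(O)c1` gives 2500 nM. Compound 2 `CC(C)(C)c1ccc(C(=O)N/N=C/c2cc(Br)ccc2O)cc1` gives > 100000 nM, which is a limit of the assay and not a number. Compound 2 thus stands at the limit of > 100000 nM in this assay, at which 1 of the 2 values shown sits. Compound 3 `Cc1ccc(O)c(/C=N/NC(=O)c2ccc(C(C)(C)C)cc2)c1` has methyl in place of bromo on an aromatic carbon, para to a hydroxy group (methyl in place of bromo on an aromatic carbon). Going by the values given here, no measured pair of compounds shows what this exchange does, and compound 1 offers no direct comparison with compound 2. The expectation therefore rests on compound 2 and its reading of > 100000 nM, with this assay likely to remain near that limit. A small move toward a lower number is expected, and the estimated change is an at least 1.4-fold lower number from compound 2 to compound 3 (0.15 log units; that floor lies within the scatter). The half-maximal cytotoxic concentration estimated for compound 3 is 70000 nM, with an expected range of 20000 nM to 100000 nM.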

Compound 3, half-maximal cytotoxic concentration: 16300 nM
For compound 3 the middle estimate is 4.3-fold (0.63 log units) above the measured one; the measured number lies below the stated range.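

Going by these compounds alone, the exchange of bromo for methyl on an aromatic carbon, para to a hydroxy group, gives the first readable step at this position: in this assay there is an at least 6.1-fold lower number from compound 2 to compound 3 (0.78 log units; beyond the scatter). The position is therefore not indifferent to this exchange, as compound 3 has a measured number and the step lies beyond the scatter. The true size of the step stays open at its upper end, since the reading for compound 2 is a limit of the assay and not a number: the limit of > 100000 nM in this assay, at which 1 of the 3 values shown sits.

The compounds shown do not separate the loss of bromo from the arrival of methyl. They also leave open how another group at this position, such as chloro, methoxy or an amine, would read in this assay.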